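The source may hold more compounds than are shown below. What is called first, only, known or untested is meant among the compounds shown, and "the series" means these compounds.

Measured compounds in an ADME assay on BCBL1 cells (Homo sapiens) for cytotoxicity, with a stated time of 7 days; on this read-out higher numbers stand for lower toxicity in this test and lower numbers for higher toxicity in this test:
- compound 1 `CNc1nc(N)nc2c1ncn2/C=C1/CC1(CO)CO` gives 67000 nM
- compound 3 `Nc1nc(NC2CC2)c2ncn(/C=C3/CC3(CO)CO)c2n1` gives 71500 nM
- compound 2 `CCOc1nc(N)nc2c1ncn2/C=C1/CC1(CO)CO` gives only a limit of the assay, > 20000 nM

Compound 1 has the lowest of the two read numbers; its nearest neighbour is compound 3, with a 1.1-fold higher number from compound 1 to compound 3 (0.03 log units; within the scatter). The step that the limit leaves unreadable from compound 1 to compound 2 cannot be read, because compound 2 sits at the limit of > 20000 nM in this assay, at which 1 of the 3 values shown sits. Likewise a step that the limit leaves unreadable from compound 2 to compound 3 is not readable.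

Compound 4 `Nc1nc(SC2CCCC2)c2ncn(/C=C3/CC3(CO)CO)c2n1` differs from compound 1 in one place: cyclopentylsulfanyl in place of methylamino on an aromatic carbon.

Among the compounds with values here, of the measured steps, only the one from compound 1 to compound 3 is readable, and it shows that enlarging the group on the nitrogen leaves this assay unchanged within the scatter. Within the data shown here, the change to compound 4 is larger, trading methylamino for cyclopentylsulfanyl, and no measured pair covers an exchange of this kind; the pair from compound 1 to compound 2, which exchanges the linking atom, gives only a limit. With nothing pointing to a direction, the expected step is a 1.1-fold lower number from compound 1 to compound 4 (0.05 log units; within the scatter), not beyond the scatter. Compound 4 is therefore estimated at 60000 nM, with a range from 20000 nM to 150000 nM.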

Compound 4, half-maximal cytotoxic concentration: > 20000 nM
Compound 4 gave a limit, no number (the forecaster's own chance of this, stated with the estimate: 30%); the middle value lies beyond the limit too.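

In this assay compound 4 gives only a limit, > 20000 nM. Within the data shown here, no step from compound 1, compound 2 or compound 3 to compound 4 can be read: the limit of > 20000 nM in this assay, at which 2 of the 4 values shown sit. The compounds shown leave open whether cyclopentylsulfanyl in place of methylamino shifts this read-out at all, and in which direction.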